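A few compounds are considered here, and "the series" means these few. Any claim that something is new, unique, unknown or untested is made for them only; others in the source may bear on it.

Measured in a functional assay on HeLa cells (Homo sapiens) for antiproliferative activity, read by MTT assay, with a stated time of 48 h; on this read-out lower numbers stand for stronger inhibition and higher numbers for weaker inhibition:
- compound 1 `Fc1ccc2[nH]c(-c3cn(-c4ccccc4)nc3-c3ccccc3)nc2c1` gives 3610 nM
- compound 2 `FC(F)(F)c1ccc2[nH]c(-c3cn(-c4ccccc4)nc3-c3ccccc3)nc2c1` gives 1920 nM
- compound 3 `Fc1ccc(-c2nn(-c3ccccc3)cc2-c2nc3cc(F)ccc3[nH]2)cc1` gives 1570 nM

Compound 3 carries the lowest number of the three, but its gap to compound 2 lies within the scatter. Only its gap to compound 1 goes beyond it, as a 2.3-fold lower number from compound 1 to compound 3 (0.36 log units; beyond the scatter) shows.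

Compound 4 `Cc1ccc2[nH]c(-c3cn(-c4ccccc4)nc3-c3ccc(F)cc3)nc2c1` has methyl in place of fluoro on an aromatic carbon of a six-membered aromatic ring of carbon only, part of a fused or bridged system of two rings (methyl in place of fluoro on an aromatic carbon). It keeps the fluoro gained in the modest step of a 2.3-fold lower number from compound 1 to compound 3 (0.36 log units; beyond the scatter). The closest evidence is the replacement of that same fluoro by trifluoromethyl, a 1.9-fold lower number from compound 1 to compound 2 (0.27 log units; within the scatter). Among the compounds with values here, no measured step brings in methyl, so this is only an indirect guide. With that one replacement staying within the scatter, no change beyond the scatter is expected in this assay. The expected step is a 1.1-fold higher number from compound 3 to compound 4 (0.06 log units; within the scatter). Compound 4 is estimated at 1800 nM, with an expected range from 800 nM to 4000 nM.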

Compound 4, half-maximal inhibitory concentration: 3630 nM
For compound 4 the middle estimate is 2.0-fold (0.30 log units) below the measured one; measured number inside the range.
By their numbers in this assay, from the lowest: compounds 3, 2, 1 and 4 (each within the scatter of the next, the first and the last beyond it).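

In this assay, within the data shown here, the exchange of fluoro for methyl on this aromatic carbon of the fused system gives a 2.3-fold higher number from compound 3 to compound 4 (0.36 log units; beyond the scatter) and is the first change at this position to pass the scatter. Among these compounds, the only earlier change here, trifluoromethyl in place of fluoro, gave a 1.9-fold lower number from compound 1 to compound 2 (0.27 log units; within the scatter) and was read on the core lacking the second fluoro, so the position proved insensitive there but not in this step. Nothing at hand accounts for the difference between fluoro and methyl at this position.

Still open, as far as these compounds go, is whether methyl would give a step of similar size on the core of compound 1, which lacks the second fluoro. Also open, from the compounds shown here alone, is how an amine, a methoxy group or a longer chain at this position would read in this assay.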